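A few compounds are considered here, and "the series" means these few. Any claim that something is new, unique, unknown or untested is made for them only; others in the source may bear on it.

Working notes on the series.

Compound 1 `OC(CCn1nc2c(Br)c(Br)c(Br)c(Br)c2n1)c1ccc(F)cc1` shows in a functional assay on MCF7 cells (Homo sapiens) for antiproliferative activity, read by MTT assay, with a stated time of 48 h, tested at 100 uM (on this read-out lower numbers stand for a stronger effect and higher numbers for a weaker effect at the one concentration tested), a read-out of 0% for compound 1. Compound 2 `OC(CCn1nc2c(Br)c(Br)c(Br)c(Br)c2n1)c1ccc(Br)cc1` differs from it only by bromo in place of fluoro on an aromatic carbon, and in this assay compound 2 gives 0%. The step of no change at the digits printed from compound 1 to compound 2 (within the scatter) is the only one measured so far. Compound 2 thus stands level with compound 1 at the digits shown, and its nearest measured neighbour in this assay is compound 1.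

Compound 3 `OC(CCn1nc2c(Br)c(Br)c(Br)c(Br)c2n1)c1ccc(Cl)cc1` is not yet measured. Its change from compound 2 is chloro in place of bromo on an aromatic carbon. Among the compounds with values here, the one step that bears on it, no change at the digits printed from compound 1 to compound 2 (within the scatter), exchanged one group at this same aromatic carbon and left the read-out in this assay unchanged within the scatter, so for compound 3 no step beyond the scatter is expected, that is no change at the digits printed from compound 2 to compound 3 (within the scatter). The estimate for compound 3 in this assay is therefore 0%, with a range from -5% to 10%.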

Compound 3, a percentage reported as activity, at one concentration (the size of the read-out at that concentration, not a potency): 0%
Estimate against measurement, compound 3: no gap at the digits printed, within the range that was stated.
By their numbers in this assay, from the lowest: compounds 1, 2 and 3 (each within the scatter of the next).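

In this assay chloro in place of bromo gives no change at the digits printed from compound 2 to compound 3 (within the scatter) and chloro in place of fluoro gives no change at the digits printed from compound 1 to compound 3 (within the scatter) on the same aromatic carbon, para to a large group. Where the earlier compounds offered a single exchange at this position, fluoro, chloro and bromo can now be compared in all three pairings, and none of the pairings separates the compounds in this read-out. Nothing available on these compounds offers an explanation for this lack of separation.

The compounds shown leave open whether an amine or a carboxylic acid on this aromatic carbon would shift the read-out, and whether a longer chain between the shared core and this ring would do so. As far as these compounds go, all three values come from one concentration, and how the three compounds compare at lower concentrations also remains open.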